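A Fourth Stereoisomer at the Limit of the Assay

This account rests on a few compounds, and the source may have more. Where it says the series, first, only, none or still open, it means among the compounds named here.

Compound 1 `Nc1ncnc2c1ncn2[C@H]1CC[C@@H](O)C1`, compound 2 `Nc1ncnc2c1ncn2[C@@H]1CC[C@H](O)C1` and compound 3 `Nc1ncnc2c1ncn2[C@@H]1CC[C@@H](O)C1` were tested in a functional assay for inhibition, with Homo sapiens as the target; on this read-out lower numbers stand for stronger inhibition and higher numbers for weaker inhibition. Compound 1 gives > 100000 nM, which is a limit of the assay. Compound 2 gives > 100000 nM, which is also a limit. Compound 3 gives > 100000 nM, again a limit, so it has no number of its own and stands with the other two.

Compound 4 `Nc1ncnc2c1ncn2[C@H]1CC[C@H](O)C1` is the mirror image of compound 3: the two compounds have the same atoms and bonds and differ only in configuration as drawn: 2 of 2 stereo elements differ (all stereocentres are inverted: mirror images); a stereocentre at a saturated ring carbon is drawn R in compound 3 and S in compound 4; a stereocentre at a saturated ring carbon is drawn R in compound 3 and S in compound 4. The nearest measured precedent is the other mirror-image pair, a step that the two limits leave unreadable from compound 1 to compound 2. The changes at a single stereocentre read the same way: a step that the two limits leave unreadable from compound 1 to compound 3 and a step that the two limits leave unreadable from compound 2 to compound 3. None of these steps has a readable size.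

Given the limit of compound 3 at > 100000 nM, no step in either direction is expected beyond the scatter in this assay. The estimated a number no higher from compound 3 to compound 4 (the limit leaves the size open) is accordingly expected to be negligible. For compound 4 the estimate is 100000 nM, expected to lie between 50000 nM and 200000 nM, and most likely to be reported only as a limit.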

Compound 4, half-maximal inhibitory concentration: > 100000 nM
Compound 4 was reported as a limit; the forecaster's own chance of this, stated with the estimate: 90%; the middle value sits exactly at the limit.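

Compound 4 stands with compound 1, compound 2 and compound 3 at the limit of this assay, so no step among these four stereoisomers can be read. The compounds shown leave open whether configuration at either stereocentre changes inhibition at all: the limit of > 100000 nM in this assay, at which 4 of the 4 values shown sit.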